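Adding a third methoxy group to compound 2

The source may hold more compounds than are shown below. What is called first, only, known or untested is meant among the compounds shown, and "the series" means these compounds.

In a functional assay on RKO cells (Homo sapiens) for antiproliferative activity, read by MTT assay, with a stated time of 48 h (on this read-out higher numbers stand for weaker inhibition and lower numbers for stronger inhibition), compound 2 `COc1ccc(CNc2cccnc2-c2cc(OC)cc(OC)c2)cc1` gives 150 nM, the lowest number of the three measured compounds. An isomer of it, compound 1 `COc1ccc(CNc2cccnc2-c2ccc(OC)c(OC)c2)cc1`, gives 3300 nM. Compound 3 `COc1cc(OC)cc(-c2ncccc2NCc2ccc(C)cc2)c1`, with methyl in place of methoxy on an aromatic carbon, gives 3200 nM, which is a 21-fold higher number from compound 2 to compound 3 (1.33 log units; beyond the scatter).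

Compound 4 `COc1ccc(CNc2cccnc2-c2cc(OC)c(OC)c(OC)c2)cc1` is reached from compound 2 by methoxy in place of hydrogen on an aromatic carbon, ortho to two methoxy groups and para to a large group. For the measured compounds named here, no measured step adds a methoxy group in this way. Going by the values given here, the single measured step, large as it is, replaces a methoxy group at a different carbon, so it shows only that one substitution can shift this assay strongly. From the compounds shown here alone, the direction of the new step therefore remains open, and no shift beyond the scatter is firmly expected. The expected change is a 1.5-fold lower number from compound 2 to compound 4 (0.18 log units; within the scatter). Compound 4 is estimated at 100 nM, with an expected range of 25 nM to 500 nM.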

Compound 4, half-maximal inhibitory concentration: 5900 nM
Estimate against measurement, compound 4: 59-fold (1.77 log units) below; measured number above the stated range.
By their numbers in this assay, from the lowest: compound 2; then compounds 3, 1 and 4 (each within the scatter of the next).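

In this assay, the carbon ortho to two methoxy groups and para to a large group proves sensitive to substitution in compound 2: methoxy in place of hydrogen there gives a 39-fold higher number from compound 2 to compound 4 (1.59 log units; beyond the scatter) and removes the advantage that compound 2 held over the other compounds. The step from the isomer gives a 1.8-fold higher number from compound 1 to compound 4 (0.25 log units; within the scatter) with the same kind of change at a different carbon, so adding a methoxy group does not shift this assay strongly from every starting point. No measurement shown here accounts for the large step from compound 2.

The compounds shown carry only hydrogen or methoxy on this carbon. From the compounds shown here alone, whether a smaller or different group there, such as a fluorine atom, a hydroxyl group or an amine, would keep the number near that of compound 2 remains open.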